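Lengthening an Alkoxy Chain on Two Related Cores

The source may report more compounds than this note shows. Statements on the series, on what has been measured and on what is new or still open speak of the compounds shown alone.

Compound 1 `CCOc1nc(C(C)(C)C)ccc1CNC(=O)C(C)c1ccc(NS(C)(=O)=O)c(F)c1` and compound 2 `CCCOc1nc(C(C)(C)C)ccc1CNC(=O)C(C)c1ccc(NS(C)(=O)=O)c(F)c1` share one core. In an assay on cells for antagonist activity at transient receptor potential cation channel subfamily V member 1 (Homo sapiens), read by FLIPR and calcium flux, with a stated time of 6 min (a lower number here means a stronger inhibitor, a higher number a weaker inhibitor), compound 1 gives 14.8 nM and compound 2 gives 1.7 nM. The change methyl in place of hydrogen on a saturated chain carbon, two bonds along the chain from an oxygen on an aromatic ring brings an 8.7-fold lower number from compound 1 to compound 2 (0.94 log units; beyond the scatter). Compound 3 `CCCOc1cc(C(C)(C)C)ccc1CNC(=O)C(C)c1ccc(NS(C)(=O)=O)c(F)c1` has a second core; the difference between the two cores is not broken down here. In this assay compound 3 gives 4.4 nM. Compound 4 `CCCCOc1cc(C(C)(C)C)ccc1CNC(=O)C(C)c1ccc(NS(C)(=O)=O)c(F)c1` is not yet measured and differs from compound 3 by methyl in place of hydrogen on a saturated chain carbon, three bonds along the chain from an oxygen on an aromatic ring, the same kind of change as that from compound 1 to compound 2, reached one bond further out, with the new methyl three bonds rather than two bonds from the oxygen on the aromatic ring. A smaller gain, a 1.8-fold lower number from compound 3 to compound 4 (0.25 log units; within the scatter), is expected, because the earlier gain of an 8.7-fold lower number from compound 1 to compound 2 (0.94 log units; beyond the scatter) rests on one pair only and the chain is now longer. Compound 4 is expected near 2.5 nM in this assay. For compound 4 a range from 0.8 nM to 8 nM is expected.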

Compound 4, inhibition constant: 1.4 nM
For compound 4 the middle estimate is 1.8-fold (0.25 log units) above the measured one; low and high end bracket the measured number.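

In this assay the longer chain again gives a lower number, a 3.1-fold lower number from compound 3 to compound 4 (0.50 log units; beyond the scatter), so the direction of the change carries over from one core to the other, but its size does not: the same change on two cores in this assay, an 8.7-fold lower number (0.94 log units; beyond the scatter) from compound 1 to compound 2 and a 3.1-fold lower number (0.50 log units; beyond the scatter) from compound 3 to compound 4, 2.8-fold (0.44 log units) apart, beyond the scatter of two such steps

This does not show that the core alone sets the size of the step. The first step is ethyl to propyl and the second is propyl to butyl, so the core and the place of the new methyl differ together, and each step rests on a single pair.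

The compounds shown leave open how a butyl chain would behave on the core of compound 1, which would help to separate these two factors. They also leave open what a longer chain, such as pentyl, would do on either core.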